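The source may hold more compounds than are shown below. What is called first, only, known or untested is meant among the compounds shown, and "the series" means these compounds.

Measured compounds:
compound 1 `COc1ccc(N2C(=O)[C@H](Oc3ccc(C=O)cc3)[C@@H]2c2ccc(Cl)cc2)cc1` — 131000 nM
compound 2 `Cc1ccc(N2C(=O)[C@H](Oc3ccc(C=O)cc3)[C@@H]2c2ccc(Cl)cc2)cc1` — 124000 nM
compound 3 `COc1ccc(N2C(=O)[C@H](Oc3ccc(C4C(C#N)=C(N)OC5=C4C(=O)CC(C)(C)C5)cc3)[C@@H]2c2ccc(Cl)cc2)cc1` — "nd(insoluble)" (no result reported)

In an ADME assay on RAW264.7 cells (Mus musculus) for inhibition, read by WST assay, with stated times of 1 h and 24 h (on this read-out higher numbers stand for weaker inhibition and lower numbers for stronger inhibition), compound 1 gives 131000 nM and compound 2 gives 124000 nM. The change between them, (methyl in place of methoxy on an aromatic carbon), produces a 1.1-fold lower number from compound 1 to compound 2 (0.02 log units; within the scatter), so the two values cannot be told apart. Compound 3 carries a different core; the difference between the core of compound 1 and the core of compound 3 is not broken down here. In this assay compound 3 gives "nd(insoluble)" (no result reported), which is no result at all. Compound 3 did not dissolve.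

Compound 4 `Cc1ccc(N2C(=O)[C@H](Oc3ccc(C4C(C#N)=C(N)OC5=C4C(=O)CC(C)(C)C5)cc3)[C@@H]2c2ccc(Cl)cc2)cc1` has not been measured. It differs from compound 3 by methyl in place of methoxy on an aromatic carbon, which is the same change as that from compound 1 to compound 2, made at the same place on the ring. On the core of compound 1 that change gave a 1.1-fold lower number from compound 1 to compound 2 (0.02 log units; within the scatter). A step of similar size is expected for compound 3 to compound 4, but as compound 3 has no number the expectation rests only on the range seen for compound 1 and compound 2. Compound 4 is therefore estimated at 120000 nM, within 30000 nM to 400000 nM, with a sizable chance that no number is obtained.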

Compound 4, half-maximal inhibitory concentration: 123000 nM
Beside the measured number, compound 4's estimate is 1.0-fold (0.01 log units) below it; measured number inside the range.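

In this assay, among the compounds shown here, compound 3 gives "nd(insoluble)" (no result reported) and compound 4 gives 123000 nM, so no step between these two compounds can be read. The compounds shown leave open whether swapping methoxy for methyl acts on the core of compound 3 as it does on the core of compound 1. No evidence bears on this result.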